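This account rests on a few compounds, and the source may have more. Where it says the series, first, only, none or still open, it means among the compounds named here.

Measured compounds:
compound 1 `O=C(CCc1cccc2c1B(O)OC2)Nc1cccc(Br)c1`, 720 nM
compound 2 `Cc1ccc(NC(=O)CCc2cccc3c2B(O)OC3)cc1Br`, 870 nM

Both values come from a functional assay on MDA-MB-231 cells (Homo sapiens) for antiproliferative activity, read by MTT assay, with a stated time of 72 h; on this read-out lower numbers stand for stronger inhibition and higher numbers for weaker inhibition. Compound 1 has the lowest of the two numbers; its nearest neighbour is compound 2, and the step of a 1.2-fold higher number from compound 1 to compound 2 (0.08 log units; within the scatter) stays within the scatter, so the two cannot be ordered. That step is the only measured one in the series, and it covers a small change, methyl in place of hydrogen on an aromatic carbon.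

Compound 3 `O=C(CCc1cccc2c1B(O)OC2)Nc1cccc(-c2ccc(C(F)(F)F)cc2)c1` differs from compound 1 by 4-(trifluoromethyl)phenyl in place of bromo on an aromatic carbon, placed on an aromatic carbon of a six-membered aromatic ring of carbon only, meta to a large group. Among the compounds with values here, no measured step touches a change of this kind, and the step from compound 1 to compound 2 is too small to bear on it. Without a precedent, no movement beyond the scatter is predicted in either direction, and the estimate is wide.

Compound 3 is expected to give about 600 nM in this assay, with a likely range of 200 nM to 2000 nM. This estimate corresponds to an expected step of a 1.2-fold lower number from compound 1 to compound 3 (0.08 log units; within the scatter).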

Compound 3, half-maximal inhibitory concentration: 510 nM
Estimate against measurement, compound 3: 1.2-fold (0.07 log units) above, and the stated range covers the measured number.
By their numbers in this assay, from the lowest: compounds 3, 1 and 2 (each within the scatter of the next).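

At the aromatic carbon that holds bromo in compound 1, this assay gives no clear response to a far larger substituent: 4-(trifluoromethyl)phenyl, with 10 heavy atoms and a ring of its own, replaces a single bromine, and the result is a 1.4-fold lower number from compound 1 to compound 3 (0.15 log units; within the scatter). Compounds 1 and 2 both carried bromo here, so only compound 3 shows that the number can stay within the scatter when an aromatic ring is added at this position. No available data bear on why the number holds across this change.

Open, on these data alone, is whether an amine or a carboxylic acid at this position would move the number beyond the scatter. Also open, as far as these compounds go, is how plain phenyl would compare with 4-(trifluoromethyl)phenyl here.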